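The compounds below may be only part of what the source reports. "The series", "measured", "known", "first", "only" and "open" are said of these compounds alone.

Compound 3, with structure `C[C@@H](NC(=O)c1ccc(C#Cc2ccncc2)cn1)C(C)(C)O`, gives 22.4% in an ADME assay on HEK293 cells for agonist activity at metabotropic glutamate receptor 5 (Rattus norvegicus), read by fluorescence and calcium flux (a higher number here means a larger maximal response, a lower number a smaller maximal response), the lowest of the three numbers measured. Compound 1 `C[C@@H](NC(=O)c1ccc(C#Cc2ccc(F)cc2)cn1)C(C)(C)O` gives 38.4%, and compound 2 `C[C@@H](NC(=O)c1ccc(C#Cc2cc(F)cc(F)c2)cn1)C(C)(C)O` gives 37.9%. The step of a number 0.5 percentage points lower from compound 1 to compound 2 (within the scatter) shows that moving from one fluorinated ring to another changes nothing beyond the scatter, while the steps of a number 16 percentage points lower from compound 1 to compound 3 (beyond the scatter) and a number 15.5 percentage points lower from compound 2 to compound 3 (beyond the scatter) show that the pyridin-4-yl group lowers the largest response by a modest amount.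

Compound 4 is `C[C@@H](NC(=O)c1ccc(C#Cc2ncccc2F)cn1)C(C)(C)O`, and it differs from compound 3 in one place: 3-fluoropyridin-2-yl in place of pyridin-4-yl on a triple-bonded carbon. For the measured compounds named here, no measured step exchanges one pyridyl ring for another, so the closest guide is that a ring carrying fluorine in this position has given the higher numbers, and a ring with a nitrogen in it the lower one. Compound 4 carries both features, so compound 4 is expected to sit between these, with an estimated step of a number 7.6 percentage points higher from compound 3 to compound 4 (within the scatter). The estimate for compound 4 is 30%, with a range from 15% to 48%.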

Compound 4, largest response reached (reported as efficacy), in percent of the reference or control that the assay uses: 29.2%
Estimate against measurement, compound 4: 0.8 percentage points above; the range from low to high includes it.
By their numbers in this assay, from the lowest: compounds 3, 4, 2 and 1 (each within the scatter of the next, the first and the last beyond it).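

In this assay, the change to 3-fluoropyridin-2-yl gives a number 6.8 percentage points higher from compound 3 to compound 4 (within the scatter), while replacing the fluorinated phenyl rings gives a number 8.7 percentage points lower from compound 2 to compound 4 (within the scatter) and a number 9.2 percentage points lower from compound 1 to compound 4 (within the scatter). Compound 4 therefore cannot be told apart from any of the other three compounds, even though compound 3 lies beyond the scatter from compound 1 and compound 2, so a ring nitrogen on the triple-bonded carbon does not always set a compound clearly apart from the fluorinated phenyl compounds. No measurement shown here explains this result.

The compounds shown leave open whether plain pyridin-2-yl, without fluorine, would read closer to compound 3 or to compound 1, so the contributions of the fluorine and of the change in ring cannot be separated. As far as these compounds go, how a pyridine ring carrying an amine or a methoxy group would behave also remains open.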